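Compound 3: trifluoromethyl in place of methoxy

The compounds below may be only part of what the source reports. "The series", "measured", "known", "first", "only" and "open" are said of these compounds alone.

Two compounds have numbers in a functional assay on MCF7 cells (Homo sapiens) for cytotoxicity, tested at 10 uM; a lower number here means less inhibition, a higher number more inhibition at the concentration tested (going by the name of the read-out). Compound 1 `O=Cc1c(-c2ccccc2)sc2ccccc12` gives 51%, and compound 2 `COc1ccc(-c2sc3ccccc3c2C=O)cc1` gives 62%. Compound 2 thus stands highest of the two numbers, with compound 1 as its nearest neighbour, lower by a step beyond the scatter. Among the compounds with values here, the one measured step is a number 11 percentage points higher from compound 1 to compound 2 (beyond the scatter), methoxy in place of hydrogen on an aromatic carbon.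

Compound 3 `O=Cc1c(-c2ccc(C(F)(F)F)cc2)sc2ccccc12` is the next entry: trifluoromethyl in place of methoxy on an aromatic carbon. Within the data shown here, no measured step replaces a methoxy with a trifluoromethyl, so the step from compound 1 to compound 2 bears on it only indirectly: it shows that a methoxy at this aromatic carbon went with a modest rise in inhibition, but it says nothing about what a trifluoromethyl at this carbon does. The expected step in this assay is therefore a number 7 percentage points lower from compound 2 to compound 3 (within the scatter), in no firm direction and not clearly beyond the scatter. For compound 3 the estimate is 55%, with a range from 40% to 70%.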

Compound 3, a percentage reported as inhibition, at one concentration (the size of the read-out at that concentration, not a potency): 73%
Estimate against measurement, compound 3: 18 percentage points below; the whole stated range lies below it.
By their numbers in this assay, from the lowest: compound 1; then compound 2; then compound 3.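

In this assay trifluoromethyl goes beyond methoxy at the same aromatic carbon, para to a large group: the exchange gives a number 11 percentage points higher from compound 2 to compound 3 (beyond the scatter) and trifluoromethyl in place of hydrogen gives a number 22 percentage points higher from compound 1 to compound 3 (beyond the scatter) in the same read-out. Both groups at this carbon now stand with higher numbers than hydrogen and also differ from each other, so the outcome depends on which group sits there and not only on the carbon carrying a substituent; a hydrogen-bond acceptor in the group is not needed for the higher number, as trifluoromethyl has none. No measurement at hand accounts for this order of the three compounds.

On these data alone, whether the rise holds for an amine, a carboxylic acid or a longer chain at this carbon stays open, as does the effect of any of these groups at other carbons of the same ring. The aldehyde carbonyl is constant across all three compounds, so its share in the read-out cannot be judged, and numbers taken at one concentration give no potency.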